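The compounds below may be only part of what the source reports. "The series", "measured", "known", "first", "only" and "open" are said of these compounds alone.

In a functional assay on L1210 cells (Mus musculus) for antiproliferative activity, with a stated time of 48 h (a higher number here means a weaker inhibitor, a lower number a stronger inhibitor), compound 1 `C=C(Br)C(=O)Nc1ccc(/C=C/C(=O)c2ccc(Cl)cc2)cc1` gives 1100 nM. Two relatives share its core: compound 2 `C=C(Br)C(=O)Nc1ccc(/C=C/C(=O)c2ccc(Br)cc2)cc1` gives 620 nM, and compound 3 `C=C(Br)C(=O)Nc1ccc(/C=C/C(=O)c2cc(OC)c(OC)c(OC)c2)cc1` gives 910 nM. The numbers of both relatives lie within the usual scatter of compound 1, so the three values do not separate it from either of them.

The next molecule is compound 4 `C=C(Br)C(=O)Nc1ccc(/C=C/C(=O)c2ccc(OCC)cc2)cc1`, which has not yet been measured. It is made from compound 1 by one exchange, ethoxy in place of chloro on an aromatic carbon.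

Among the compounds with values here, only one measured step changes a single place in compound 1, and it concerns the same chloro group. That step, bromo in place of chloro, amounts to a 1.8-fold lower number from compound 1 to compound 2 (0.25 log units; within the scatter). No single change links compound 1 to compound 3, but compound 3 gives 910 nM, which shows that a quite different substitution also stayed within the scatter of compound 1. Within the data shown here, no measured compound carries ethoxy, so these data can only weakly guide the expectation, and the range has to stay wide.

No change beyond the scatter is expected, and the estimated step is a 1.4-fold lower number from compound 1 to compound 4 (0.14 log units; within the scatter). The expected value for compound 4 is 800 nM, with an estimated range from 300 nM to 2000 nM.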

Compound 4, half-maximal inhibitory concentration: 240 nM
For compound 4 the middle estimate is 3.3-fold (0.52 log units) above the measured one; the whole stated range lies above it.
By their numbers in this assay, from the lowest: compound 4; then compounds 2, 3 and 1 (each within the scatter of the next).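

In this assay the place para to a large group, which holds chloro in compound 1, proves responsive to the group sitting on it: ethoxy gives a 4.6-fold lower number from compound 1 to compound 4 (0.66 log units; beyond the scatter) and, against the bromo relative, a 2.6-fold lower number from compound 2 to compound 4 (0.41 log units; beyond the scatter) with both steps beyond the scatter. The exchange of chloro for bromo, a 1.8-fold lower number from compound 1 to compound 2 (0.25 log units; within the scatter) stayed within the scatter, so swapping one of these halogens for the other did not separate the compounds, while replacing either with ethoxy, which has more heavy atoms and brings one hydrogen-bond acceptor, did. Nothing measured here accounts for this difference.

Going by these compounds, how a single methoxy, a longer chain such as butoxy, or an amine at this same place would compare with ethoxy remains open, so it cannot be said whether the effect is particular to ethoxy or is shared by related groups. Compound 3 differs from the others in more than one place, so it cannot settle that question.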